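This account rests on a few compounds, and the source may have more. Where it says the series, first, only, none or still open, it means among the compounds named here.

Measured compounds:
- Compound 1 `Cc1ccc(NC(=O)NC(=O)c2ccc(OCc3cccc(C(F)(F)F)c3)cc2)cc1-c1nc2ccccc2[nH]1`: 13100 nM
- Compound 2 `Cc1ccc(NC(=O)NC(=O)c2ccc(OCc3cccc(F)c3)cc2)cc1-c1nc2ccccc2[nH]1`: 44800 nM

Both were tested in a functional assay on MGC-803 cells (Homo sapiens) for inhibition, read by MTT assay, with a stated time of 48 h; on this read-out lower numbers stand for stronger inhibition and higher numbers for weaker inhibition. Compound 1 gives 13100 nM, while compound 2 gives 44800 nM. Among the two numbers measured, compound 2 stands highest, which on this read-out means weaker inhibition; the single step connecting them, a 3.4-fold higher number from compound 1 to compound 2 (0.53 log units; beyond the scatter), lies beyond the scatter, so compound 1 and compound 2 are genuinely apart.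

Compound 3 `Cc1ccc(NC(=O)NC(=O)c2ccc(OCc3ccc(Cl)cc3Cl)cc2)cc1-c1nc2ccccc2[nH]1` has not yet been measured in this assay. It differs from compound 2 in one place: 2,4-dichlorophenyl in place of 3-fluorophenyl on a saturated chain carbon bound to an oxygen on an aromatic ring. Among the measured compounds shown here, the only measured step that bears on this change is a 3.4-fold higher number from compound 1 to compound 2 (0.53 log units; beyond the scatter), which shows that replacing trifluoromethyl by fluoro at that ring weakened inhibition modestly. Moving on from fluoro to two chlorines on the same ring is a change of a similar kind, so a step back towards a lower number is expected, roughly undoing what that earlier step did. For compound 3 the expected step is a 3.0-fold lower number from compound 2 to compound 3 (0.48 log units; beyond the scatter). Compound 3 is therefore estimated at 15000 nM, with a likely range of 5000 nM to 45000 nM.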

Compound 3, half-maximal inhibitory concentration: 2740 nM
Compound 3: the middle estimate sits 5.5-fold (0.74 log units) above what was measured; the measured number lies below the stated range.
By their numbers in this assay, from the lowest: compound 3; then compound 1; then compound 2.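

In this assay the ring on the saturated chain carbon bound to an oxygen on an aromatic ring proves more sensitive than the first step suggested, with a 16-fold lower number from compound 2 to compound 3 (1.21 log units; beyond the scatter) as the change from 3-fluorophenyl to 2,4-dichlorophenyl. The new ring does more than win back what was lost on going from trifluoromethyl to fluoro: the direct comparison with 3-(trifluoromethyl)phenyl gives a 4.8-fold lower number from compound 1 to compound 3 (0.68 log units; beyond the scatter) and makes compound 3 the strongest inhibitor of the three on this read-out. Nothing measured on these compounds accounts for this gain.

The three rings differ at once in the kind of substituent, in how many there are and in where they sit, so these compounds cannot show which of these matters, or whether a ring carrying a single chlorine would capture the gain. Going by these compounds, how a plain phenyl ring, or one carrying a methoxy group or a nitrile, would compare also remains open.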